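A few compounds are considered here, and "the series" means these few. Any claim that something is new, unique, unknown or untested is made for them only; others in the source may bear on it.

Three compounds have been measured in an assay on CHO cells for displacement of a labelled ligand from adenosine receptor A1 (Homo sapiens), read by scintillation counting, with a stated time of 90 min, tested at 1 uM, in the presence of a further agent that is not named here; on this read-out higher numbers stand for more inhibition at the one concentration tested (going by the name of the read-out) and lower numbers for less inhibition:

Compound 1, `CCCn1c(=O)c2[nH]c(-c3ccc(S(=O)(=O)N4CCN(c5ccc(Cl)cc5)CC4)cc3)nc2n(C)c1=O`, gives 22%.
Compound 2, `CCCn1c(=O)[nH]c2nc(-c3ccc(S(=O)(=O)N4CCN(c5ccc(Br)cc5)CC4)cc3)[nH]c2c1=O`, gives 13%.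
Compound 3, `CCCn1c(=O)[nH]c2nc(-c3ccc(S(=O)(=O)N4CCN(c5ccccc5)C(C)C4)cc3)[nH]c2c1=O`, gives 15%.

All three share a core and differ only in the group that sits on the amine nitrogen of the six-membered ring with two nitrogens. On these numbers compound 2 stands no further from compound 3 or from compound 1 than the usual scatter of repeated measurements, so the three results cannot be told apart with any confidence; none of them shows strong displacement of the labelled ligand at the single concentration tested.

The next compound, compound 4, `CCCn1c(=O)[nH]c2nc(-c3ccc(S(=O)(=O)N4CCN(c5cccc(Cl)c5)CC4)cc3)[nH]c2c1=O`, is a close relative of compound 2. The change is 3-chlorophenyl in place of 4-bromophenyl on an amine nitrogen in a ring. The halogen changes from bromine to chlorine and its place on the phenyl ring changes as well, while the count of heavy atoms, the ring, and the absence of donors, acceptors and charge stay the same.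

Among the measured compounds shown here, no pair of measured compounds that differ in just one place is available here, so there is no measured step to lean on. Since all three measured compounds sit within the scatter of one another, the change from compound 2 to compound 4 is expected to give a step of no more than the scatter, a number 2 percentage points higher from compound 2 to compound 4 (within the scatter), in either direction. Compound 4 is therefore estimated at 15%, with a range from 3% to 30%.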

Compound 4, a percentage reported as inhibition, at one concentration (the size of the read-out at that concentration, not a potency): 21%
Estimate against measurement, compound 4: 6 percentage points below; the measured number falls inside the stated range.
By their numbers in this assay, from the lowest: compounds 2, 3, 4 and 1 (each within the scatter of the next).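

In this assay, among the compounds shown here, placing 3-chlorophenyl where 4-bromophenyl stood on an amine nitrogen in a ring gives a number 8 percentage points higher from compound 2 to compound 4 (within the scatter), the first step here that compares two compounds differing in only one place. This single change alters both the halogen and its place on the phenyl ring, yet the result stays within the usual scatter, so this pair gives no sign that the read-out responds to the swap at the one concentration tested. Nothing measured here bears on how either group acts at this position.

The halogen and its place on the phenyl ring changed together, so the compounds shown leave open what each of the two changes contributes on its own. They also leave open how this assay would respond to a different kind of group on this nitrogen, such as a benzyl group or a longer alkyl chain ending in an amine or a carboxylic acid.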